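The source may report more compounds than this note shows. Statements on the series, on what has been measured and on what is new or still open speak of the compounds shown alone.

For the measured compounds named here, compound 2 `Cc1cc(S(=O)(=O)/N=C(\N)n2nccc2-c2ccccc2)c(SCc2ccccc2C)cc1Cl` stands highest of the two numbers so far in a functional assay on HCT-116 cells (Homo sapiens) for cytotoxicity, read by MTT assay, with a stated time of 72 h (a lower number here means a stronger inhibitor, a higher number a weaker inhibitor), where compound 2 gives 16000 nM. Its nearest neighbour is compound 1 `Cc1cccc(CSc2cc(Cl)c(C)cc2S(=O)(=O)/N=C(\N)n2nccc2-c2ccccc2)c1`, which in this assay gives 6500 nM; the step of a 2.5-fold higher number from compound 1 to compound 2 (0.39 log units; beyond the scatter) is a modest rise. Compound 3 `Cc1cc(S(=O)(=O)/N=C(\N)n2nccc2-c2ccccc2)c(SCc2ccccc2C(F)(F)F)cc1Cl` differs from compound 2 in one place: trifluoromethyl in place of methyl on an aromatic carbon. Going by the values given here, no measured step touches this group; the only step in hand, a 2.5-fold higher number from compound 1 to compound 2 (0.39 log units; beyond the scatter), shifts the methyl from 3-methylphenyl to 2-methylphenyl and so offers no guide to swapping methyl for trifluoromethyl. With nothing to point either way, the expected step is no change at the digits printed from compound 2 to compound 3 (within the scatter), one that stays within the scatter, and the uncertainty is wide. Compound 3 is therefore estimated to give 16000 nM in this assay, with a range from 5000 nM to 50000 nM.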

Compound 3, half-maximal inhibitory concentration: 16000 nM
Estimate against measurement, compound 3: no gap at the digits printed, within the range that was stated.
By their numbers in this assay, from the lowest: compound 1; then compounds 2 and 3 (each within the scatter of the next).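

In this assay, trifluoromethyl in place of methyl on this aromatic carbon, ortho to a large group, gives no change at the digits printed from compound 2 to compound 3 (within the scatter), so 2-(trifluoromethyl)benzyl and 2-methylbenzyl on the sulfur cannot be told apart here. The step of a 2.5-fold higher number from compound 1 to compound 3 (0.39 log units; beyond the scatter) is the same size as the step of a 2.5-fold higher number from compound 1 to compound 2 (0.39 log units; beyond the scatter), so among these three compounds, both 2-substituted groups stand apart from the 3-methylphenyl group of compound 1. No evidence is available to explain this result.

From the compounds shown here alone, it remains open whether a smaller or more polar group on this carbon, such as fluorine, a hydroxyl or an amine, would also leave the number in the same place. Going by these compounds, it is also open whether trifluoromethyl in place of the methyl of the 3-methylphenyl group of compound 1 would match that compound.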